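Cytotoxicity notes on the sulfonamide series: compound 2 to compound 4

The source may hold more compounds than are shown below. What is called first, only, known or untested is meant among the compounds shown, and "the series" means these compounds.

The series is followed in an ADME assay on Huh-7 cells (Homo sapiens) for cytotoxicity, with a stated time of 72 h; on this read-out lower numbers stand for higher toxicity in this test and higher numbers for lower toxicity in this test. Compound 1 `CC(C)(C)CCN1C(=O)C(C2=NS(=O)(=O)c3cc(NS(C)(=O)=O)ccc3N2)=C(O)C2CCCCCCC21` has no result in this assay, its entry reading "not determined" (no result reported). For compound 2 `CC(C)CCN1C(=O)C(C2=NS(=O)(=O)c3cc(NS(C)(=O)=O)ccc3N2)=C(O)C2CCCC21` this assay reports only a limit, > 1000 nM, and not a single number. For compound 3 `CS(=O)(=O)Nc1ccc2c(c1)S(=O)(=O)N=C(C1=C(O)[C@H]3CCC[C@H]3N(Cc3cccc(C(F)(F)F)c3)C1=O)N2` the entry is again a limit, > 33000 nM, so no number stands for it either. Compound 2 thus sits at one of the two limits shown, (the limit of > 1000 nM in this assay, at which 1 of the 3 values shown sits), while the other limit, (the limit of > 33000 nM in this assay, at which 1 of the 3 values shown sits), belongs to compound 3; neither entry gives a point value that could be ordered against the other.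

Compound 4 `CS(=O)(=O)Nc1ccc2c(c1)S(=O)(=O)N=C(C1=C(O)C3CCCC3N(Cc3ccccn3)C1=O)N2` is the unmeasured member. It differs from compound 2 in one place: pyridin-2-yl in place of isobutyl on a saturated chain carbon bound to an amide-type nitrogen in a ring. Among the measured compounds shown here, no step between two measured compounds is given, so no measured step can be used as a guide for the size of the change in this assay.

Given that compound 2 and compound 3 each report only a limit, compound 4 is expected to report a limit as well, with the estimated step being a step that the limit leaves unreadable from compound 2 to compound 4. The estimate for compound 4 in this assay is 20000 nM, within a range from 3000 nM to 100000 nM.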

Compound 4, half-maximal cytotoxic concentration: > 33000 nM
Compound 4: a limit, no number (the forecaster's own chance of this, stated with the estimate: 75%); middle value at least 1.6-fold (0.21 log units) from the limit.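

In this assay compound 4 reports > 33000 nM, which is a limit and not a number. Compound 2 also reports a limit, > 1000 nM, so no step can be read from compound 2 to compound 4. The compounds shown leave open whether pyridin-2-yl in place of isobutyl changes the half-maximal cytotoxic concentration at all.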